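A few compounds are considered here, and "the series" means these few. Any claim that something is new, unique, unknown or untested is made for them only; others in the source may bear on it.

Working notes on the series. In a functional assay on MCF7 cells (Homo sapiens) for antiproliferative activity, read by sulforhodamine B assay, with a stated time of 48 h (on this read-out higher numbers stand for weaker inhibition and lower numbers for stronger inhibition), compound 3 `CCCCCCCc1ccc(NS(=O)(=O)c2ccc(N3CCNC3=O)cc2)cc1` is known only as a limit, > 1000 nM. Compound 1 `O=C1NCCN1c1ccc(S(=O)(=O)Nc2ccc(C3CCCCC3)cc2)cc1` carries cyclohexyl where compound 3 carries heptyl. Compound 1 is also known only as a limit, > 1000 nM. Going by the values given here, both compounds sit at the limit of > 1000 nM in this assay, at which 2 of the 3 values shown sit, and the one measured step, a step that the two limits leave unreadable from compound 1 to compound 3, therefore gives no size to carry forward. Compound 2 `Cc1cccc(NS(=O)(=O)c2ccc(N3CCNC3=O)cc2)c1`, with a much smaller group than either, is the only one of the three with a number, 190 nM.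

Compound 4 `O=C1NCCN1c1ccc(S(=O)(=O)Nc2ccc(Cl)cc2)cc1` differs from compound 3 as follows: chloro in place of heptyl on an aromatic carbon. This is chloro in place of heptyl on an aromatic carbon, para to a large group. Among the compounds with values here, no measured step covers this change directly. The nearest guide is compound 2 at 190 nM, which shows that a compound of this series with a small group can give a number in this assay. The expected step is an at least 2.0-fold lower number from compound 3 to compound 4 (0.30 log units; that floor lies within the scatter), in the direction of stronger inhibition. Its size is only loosely defined, as the starting point is a limit, and a second limit remains possible. The estimate for compound 4 is 500 nM, with an expected range of 100 nM to 2500 nM.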

Compound 4, half-maximal inhibitory concentration: 170 nM
Beside the measured number, compound 4's estimate is 2.9-fold (0.47 log units) above it; the measured number falls inside the stated range.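

In this assay, this aromatic carbon now gives a readable change: chloro in place of heptyl gives an at least 5.8-fold lower number from compound 3 to compound 4 (0.76 log units; beyond the scatter), and chloro in place of cyclohexyl gives an at least 5.8-fold lower number from compound 1 to compound 4 (0.76 log units; beyond the scatter). Compound 1 and compound 3 remain limits, so both sizes are floors and not measured distances: the limit of > 1000 nM in this assay, at which 2 of the 4 values shown sit. Moving from the 3-methylphenyl of compound 2 to the 4-chlorophenyl of compound 4 gives a 1.1-fold lower number from compound 2 to compound 4 (0.05 log units; within the scatter), so these two compounds cannot be told apart, and among the four shown the two with a number carry chloro or methyl, the two at the limit carry heptyl or cyclohexyl, and no compound goes against this.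

Open, going by these compounds, is how the number moves between chloro and heptyl at this carbon, and a shorter chain such as ethyl, an amine or a carboxylic acid there would show whether the change is gradual or abrupt. The step between the heptyl and cyclohexyl compounds cannot be read, so the compounds shown do not rank those two groups against each other.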